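This account rests on a few compounds, and the source may have more. Where it says the series, first, only, none or still open, it means among the compounds named here.

Compound 1 `CCc1cc(CN2CC(C(=O)O)C2)sc1-c1cc(-c2ccc(Oc3ccccc3)cc2)on1` gives 2% in a functional assay on the whole organism (spleen, spleen, strain LEW) for inhibition, with Rattus norvegicus as the target, with a stated time of 4 days, at a dose of 1 mg/kg by the oral route; a lower number here means less inhibition, a higher number more inhibition at the dose given (going by the name of the read-out). Compound 2 `CCc1cc(CN2CC(C(=O)O)C2)sc1-c1ncc(-c2ccc(OC(C)C)cc2)s1` gives 52% in this assay. Compound 3 `CCCc1cc(-c2cnc(-c3sc(CN4CC(C(=O)O)C4)cc3CC)s2)ccc1OC(C)C` gives 73% in this assay, the highest of the three numbers, with compound 2 nearest and compound 1 furthest, both beyond the scatter. Going by the values given here, the only single-change step measured is a number 21 percentage points higher from compound 2 to compound 3 (beyond the scatter), beyond the scatter and modest in size.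

Compound 4 `CCc1cc(CN2CC(C(=O)O)C2)sc1-c1ncc(-c2ccc(OC(C)C)c(Cl)c2)s1` differs from compound 3 by chloro in place of propyl on an aromatic carbon. The step of a number 21 percentage points higher from compound 2 to compound 3 (beyond the scatter) bears directly on this carbon, since it shows what filling it with propyl did against hydrogen. Among the compounds with values here, no measured step tells whether chloro, one heavy atom in place of three, behaves like propyl or like hydrogen there. The expectation is therefore a number lying between those of compound 2 and compound 3, a downward step a number 13 percentage points lower from compound 3 to compound 4 (beyond the scatter) of uncertain size that may or may not exceed the scatter. Compound 4 is estimated at 60%, with a range from 40% to 78%.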

Compound 4, a percentage reported as inhibition, in the whole organism at one dose (the size of the read-out at that dose, not a potency): 54%
The estimate for compound 4 lay 6 percentage points above the measured number; measured number inside the range.
By their numbers in this assay, from the lowest: compound 1; then compounds 2 and 4 (each within the scatter of the next); then compound 3.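

In this assay, chloro on this aromatic carbon, ortho to an isopropoxy group, reads like hydrogen rather than propyl: chloro in place of hydrogen gives a number 2 percentage points higher from compound 2 to compound 4 (within the scatter), and chloro in place of propyl gives a number 19 percentage points lower from compound 3 to compound 4 (beyond the scatter). Across compound 2, compound 3 and compound 4, then, a substituent on this carbon is not enough for a number beyond the scatter of the unsubstituted compound; of the two substituents shown, only propyl does this. Nothing available explains the difference between propyl and chloro.

Open, on these data alone, is whether the number follows chain length at this carbon, which ethyl and butyl would test. Also open, as far as these compounds go, is how methoxy or an amine would read here, and whether propyl gives a similar step on other cores.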